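This account rests on a few compounds, and the source may have more. Where it says the series, first, only, none or still open, it means among the compounds named here.

Of the compounds shown here, three sharing one core have been tested in a functional assay on HL-60 cells (Homo sapiens) for antiproliferative activity; on this read-out higher numbers stand for weaker inhibition of growth and lower numbers for stronger inhibition of growth. There, compound 1 `COCCCCCCCCCCC/C=C1\CC(CO)(COC(=O)C(C)(C)C)OC1=O` gives 5.22 ug/mL. Compound 2 `COC(=O)CCCCCCCCCCCCCC/C=C1\CC(CO)(COC(=O)C(C)(C)C)OC1=O` gives only a limit, > 10 ug/mL. Compound 3 `CCCCCCCCC(O)CCCCCC/C=C1\CC(CO)(COC(=O)C(C)(C)C)OC1=O` also gives only a limit, > 10 ug/mL, which is the limit of > 10 ug/mL in this assay, at which 2 of the 3 values shown sit.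

The change from compound 3 to compound 4 `CC(C)(C)C(=O)OCC1(CO)C/C(=C\CCCCCCCCCCCO)C(=O)O1` is 5-hydroxypentyl in place of 1-hydroxynonyl on a saturated chain carbon, six bonds along the chain from a double-bonded chain carbon. Here 5-hydroxypentyl stands in place of 1-hydroxynonyl on a saturated chain carbon, six bonds along the chain from a double-bonded chain carbon.

For the measured compounds named here, two measured steps bear on this change. One is an at least 1.9-fold higher number from compound 1 to compound 3 (0.28 log units; that floor lies within the scatter), where 1-hydroxynonyl replaced 5-methoxypentyl at that same place. The other is an at least 1.9-fold higher number from compound 1 to compound 2 (0.28 log units; that floor lies within the scatter). Neither step is shown to exceed the scatter, so both give only weak guidance. Compound 4 keeps the hydroxyl of compound 3, but its 5-hydroxypentyl matches the length of the 5-methoxypentyl in compound 1, which gives 5.22 ug/mL.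

A modest move towards stronger inhibition of growth is therefore expected, as an at least 1.4-fold lower number from compound 3 to compound 4 (0.15 log units; that floor lies within the scatter). The estimated value for compound 4 is 7 ug/mL, within an expected range of 3 ug/mL to 15 ug/mL.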

Compound 4, concentration for 50% growth inhibition: > 10 ug/mL
Compound 4: no number, only a limit (the forecaster's own chance of this, stated with the estimate: 35%); middle value at least 1.4-fold (0.15 log units) away from the limit.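

Setting hydrogen in place of methyl on an oxygen on a saturated carbon gives an at least 1.9-fold higher number from compound 1 to compound 4 (0.28 log units; that floor lies within the scatter), so in this assay this change cannot be told apart from the usual scatter. For the compounds shown here, the value of compound 4 is a limit and not a number, which leaves compound 1 as the only compound here with a true value; the steps to compound 4 from compound 2 and compound 3 cannot be read, since both ends of each are limits. The series now gathers at one ceiling: the limit of > 10 ug/mL in this assay, at which 3 of the 4 values shown sit.

On these data alone, how much growth inhibition compound 4 actually gives stays open, as does whether the methyl on the chain-end oxygen of compound 1 matters at all. An ethyl ether, an amine or a carboxylic acid at that chain end would help to settle this, provided the values fall within the readable range.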